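A few compounds are considered here, and "the series" means these few. Any claim that something is new, unique, unknown or untested is made for them only; others in the source may bear on it.

Working notes on a series of four compounds built on a common core. Compound 1 `C=C1CC[C@H]2C(C)(C)CCC[C@]2(C)[C@H]1CC/C(C)=C/Cc1c(O)cc(O)c2c(=O)c(O)c(-c3ccc(O)cc3)oc12` gives in a functional assay on HeLa cells (Homo sapiens) for cytotoxicity, read by XTT assay, with a stated time of 72 h (a lower number here means a stronger inhibitor, a higher number a weaker inhibitor), a value of 30000 nM. Compound 3 `C=C1CC[C@H]2C(C)(C)CCC[C@]2(C)[C@H]1CC/C(C)=C/COc1cc(O)c2c(=O)c(O)c(-c3ccc(O)cc3)oc2c1` reaches only a limit of this assay, > 100000 nM. Compound 2 `C=C1CC[C@H]2C(C)(C)CCC[C@]2(C)[C@H]1CC/C(C)=C/COc1cc(O)c2c(=O)c(O)c(-c3ccc(OC)cc3)oc2c1` likewise reaches only a limit of this assay, > 100000 nM. The change from compound 3 to compound 2 is methyl in place of hydrogen on an oxygen on an aromatic ring, and its step that the two limits leave unreadable from compound 3 to compound 2 cannot be read because of the limit of > 100000 nM in this assay, at which 2 of the 3 values shown sit. How the core of compound 1 differs from that of compound 3 is not broken down here. Compound 4 `C=C1CC[C@H]2C(C)(C)CCC[C@]2(C)[C@H]1CC/C(C)=C/Cc1c(O)cc(O)c2c(=O)c(O)c(-c3ccc(OC)cc3)oc12` carries the same kind of change on the core of compound 1, (methyl in place of hydrogen on an oxygen on an aromatic ring), at a place described in the same words. Among the compounds with values here, with the one measured instance unreadable, the step from compound 1 to compound 4 in this assay is expected to be a 1.3-fold higher number from compound 1 to compound 4 (0.12 log units; within the scatter). Compound 4 is accordingly estimated at 40000 nM, between 15000 nM and 150000 nM.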

Compound 4, half-maximal inhibitory concentration: > 100000 nM
Compound 4: no number, only a limit; the forecaster's own chance of this, stated with the estimate: 35%; middle value at least 2.5-fold (0.39 log units) from the limit.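

On the core of compound 1, the change from hydroxy to methoxy gives, in this assay, an at least 3.3-fold higher number from compound 1 to compound 4 (0.52 log units; beyond the scatter). Compound 4 gives > 100000 nM, which is a limit of the assay and not a number, so the step has a lower bound but no full size. The step on the core of compound 3 cannot be read, so the data show the change on the core of compound 1 only and do not show whether its size carries from one core to the other: the limit of > 100000 nM in this assay, at which 3 of the 4 values shown sit.

Open, from the compounds shown here alone, is how the core of compound 1 would respond to an amine in place of this hydroxy. Also open, going by these compounds, is whether a longer chain on that oxygen would read differently from methyl.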